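The compounds below may be only part of what the source reports. "The series", "measured", "known", "first", "only" and "open" are said of these compounds alone.

In an ADME assay on Vero cells (Chlorocebus sabaeus) for cytotoxicity, read by MTT assay, with a stated time of 48 h (a lower number here means a stronger inhibitor, a higher number a weaker inhibitor), compound 3 (`CC(=O)NC1CCC(CN2CCN(c3cc(=O)c4cc(C(F)(F)F)cc([N+](=O)[O-])c4s3)CC2)CC1`) is reported only as a limit, > 64 ug/mL. Compound 1 (`O=C(OC1CCC(CN2CCN(c3cc(=O)c4cc(C(F)(F)F)cc([N+](=O)[O-])c4s3)CC2)CC1)C1CCC1`) is also reported only as a limit, > 64 ug/mL. Compound 2 (`O=c1cc(N2CCN(CC3CCC(OS(=O)(=O)c4ccc5c(c4)CCO5)CC3)CC2)sc2c([N+](=O)[O-])cc(C(F)(F)F)cc12`) is likewise a limit, > 64 ug/mL. The readings so far therefore amount to the limit of > 64 ug/mL in this assay, at which 3 of the 3 values shown sit, and no number is available for any of the three.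

Compound 4 (`O=C(OC1CCC(CN2CCN(c3cc(=O)c4cc(C(F)(F)F)cc([N+](=O)[O-])c4s3)CC2)CC1)c1ccc(F)cc1`) carries ((4-fluorophenyl)carbonyl)oxy in place of acetamido on a saturated ring carbon.

Among the measured compounds shown here, two measured steps bear on this change. For the measured compounds named here, the first is a step that the two limits leave unreadable from compound 1 to compound 3, which exchanges acetamido and (cyclobutylcarbonyl)oxy on a saturated ring carbon. The second is a step that the two limits leave unreadable from compound 1 to compound 2, which brings in a larger group on an oxygen on a saturated carbon. Neither step has a readable size, and neither leaves the limit. On that basis, no shift beyond the scatter and no direction are expected in this assay, and the expected step is a number no higher from compound 3 to compound 4 (the limit leaves the size open).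

For compound 4 the estimate is 64 ug/mL, with an expected range of 32 ug/mL to 128 ug/mL.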

Compound 4, half-maximal inhibitory concentration: > 64 ug/mL
Compound 4 gave a limit, no number (the forecaster's own chance of this, stated with the estimate: 85%); the middle value lies on the limit itself.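

In this assay compound 4 gives only a limit, so the steps to it from compound 1, compound 2 and compound 3 cannot be read, and all four compounds share one reading: the limit of > 64 ug/mL in this assay, at which 4 of the 4 values shown sit. The compounds shown leave open where any of them would give an actual number, and whether these group changes shift it.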